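Swapping a Dichlorobenzyl Ether for an Anilide on the Core

A few compounds are considered here, and "the series" means these few. Any claim that something is new, unique, unknown or untested is made for them only; others in the source may bear on it.

Of the compounds shown here, three sharing one core have been measured in a functional assay on HEK293 cells for agonist activity at G-protein coupled receptor 39 (Homo sapiens), read by scintillation proximity assay and inositol phosphate accumulation, with a stated time of 75 min, in the presence of a further agent that is not named here; on this read-out higher numbers stand for an effect only at larger amounts of compound and lower numbers for an effect already at smaller amounts. Compound 1 `Cc1nn(-c2ncnc3nc[nH]c23)c2c1C(c1ccc(OC(C)C)cc1)CC(=O)N2` gives 18 nM, compound 2 `Cc1nn(-c2ncnc3nc[nH]c23)c2c1C(C(=O)NCc1ccc(F)cc1)CC(=O)N2` gives 4 nM, and compound 3 `Cc1nn(-c2ncnc3nc[nH]c23)c2c1C(OCc1ccc(Cl)cc1Cl)CC(=O)N2` gives 4 nM. Compound 3 stands level with compound 2, the two lowest numbers, and the step of a 4.5-fold lower number from compound 1 to compound 3 (0.65 log units; beyond the scatter) was modest but beyond the scatter. Compound 4 `Cc1nn(-c2ncnc3nc[nH]c23)c2c1C(C(=O)Nc1ccccc1)CC(=O)N2` differs from compound 3 in one place: phenylcarbamoyl in place of (2,4-dichlorobenzyl)oxy on a saturated ring carbon. For the measured compounds named here, no measured step covers this exact swap; the closest comparison is compound 2, whose side group also holds an amide and which gives 4 nM. Compound 4 is therefore expected to stay near that level, with a 1.5-fold higher number from compound 3 to compound 4 (0.18 log units; within the scatter) expected to lie within the scatter. The estimate for compound 4 is 6 nM, with a range from 2 nM to 20 nM.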

Compound 4, half-maximal effective concentration: 10 nM
Beside the measured number, compound 4's estimate is 1.7-fold (0.22 log units) below it, within the range that was stated.
By their numbers in this assay, from the lowest: compounds 2 and 3 (each within the scatter of the next); then compounds 4 and 1 (each within the scatter of the next).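

At this saturated ring carbon in this assay, an amide alone does not keep the number at the level of compound 2 and compound 3: phenylcarbamoyl for (2,4-dichlorobenzyl)oxy gives a 2.5-fold higher number from compound 3 to compound 4 (0.40 log units; beyond the scatter) here. What sits on the amide nitrogen also matters, with a 2.5-fold higher number from compound 2 to compound 4 (0.40 log units; beyond the scatter) on changing 4-fluorobenzyl to phenyl, whereas a 1.8-fold lower number from compound 1 to compound 4 (0.26 log units; within the scatter) does not separate these two compounds. No supporting evidence explains these steps. Going by these compounds, whether a longer chain on the amide nitrogen would restore the lower number remains open. So does how a carboxylic acid or an amine at this ring carbon would compare.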